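Adding a Third Methoxy Group: Expectation for Compound 4

A few compounds are considered here, and "the series" means these few. Any claim that something is new, unique, unknown or untested is made for them only; others in the source may bear on it.

Three compounds sharing one core were measured in a functional assay on OVCAR-8 cells (Homo sapiens) for antiproliferative activity, with a stated time of 48 h; on this read-out higher numbers stand for weaker inhibition of growth and lower numbers for stronger inhibition of growth:

Compound 1 `Cc1cc(O)c(C2=NN(c3ccc(S(N)(=O)=O)cc3)C(c3ccccc3O)C2)cc1Cl` gives 16500 nM.
Compound 2 `Cc1cc(O)c(C2=NN(c3ccc(S(N)(=O)=O)cc3)C(/C=C/c3ccccc3)C2)cc1Cl` gives 20200 nM.
Compound 3 `COc1ccc(C2CC(c3cc(Cl)c(C)cc3O)=NN2c2ccc(S(N)(=O)=O)cc2)cc1OC` gives 17900 nM.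

Compound 3 holds the middle number of the three. The step from compound 1 to compound 3 is a 1.1-fold higher number from compound 1 to compound 3 (0.04 log units; within the scatter), and the step from compound 2 to compound 3 is a 1.1-fold lower number from compound 2 to compound 3 (0.05 log units; within the scatter); the step from compound 1 to compound 2 is a 1.2-fold higher number from compound 1 to compound 2 (0.09 log units; within the scatter). Every change tried so far swaps the whole group on the saturated ring carbon, and none moves the number beyond the scatter.

Compound 4 `COc1ccc(C2CC(c3cc(Cl)c(C)cc3O)=NN2c2ccc(S(N)(=O)=O)cc2)c(OC)c1OC` differs from compound 3 by a smaller change: methoxy in place of hydrogen on an aromatic carbon. Read one bond further out, 3,4-dimethoxyphenyl becomes 2,3,4-trimethoxyphenyl. Within the data shown here, no measured step adds a group to this aromatic ring, so no step bears directly on it; the nearest evidence is that far larger changes at this position, from compound 1 to compound 3 and from compound 2 to compound 3, stayed within the scatter. On that basis compound 4 is expected to show a step of about a 1.0-fold higher number from compound 3 to compound 4 (0.00 log units; within the scatter), that is, nothing beyond the scatter. The estimate for compound 4 in this assay is 18000 nM, in a range from 9000 nM to 36000 nM.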

Compound 4, concentration for total growth inhibition: 12900 nM
Compound 4: middle estimate off by 1.4-fold (0.14 log units), on the high side; low and high end bracket the measured number.
By their numbers in this assay, from the lowest: compounds 4, 1, 3 and 2 (each within the scatter of the next).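

In this assay, among these compounds, this is the first step that adds a group to the aromatic ring on the saturated ring carbon instead of swapping the whole group, and placing a methoxy on an aromatic carbon, ortho to a large group, still stays within the scatter (a 1.4-fold lower number from compound 3 to compound 4 (0.14 log units; within the scatter)). The whole-group swaps to 2,3,4-trimethoxyphenyl also stay within it (a 1.6-fold lower number from compound 2 to compound 4 (0.19 log units; within the scatter); a 1.3-fold lower number from compound 1 to compound 4 (0.11 log units; within the scatter)), so this position has now met both a small addition and large replacements without a step that can be told apart from the usual variation between repeats. Nothing measured here offers an explanation for how small these steps are.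

On these data alone, what remains open is whether a methoxy on this aromatic carbon would give the same number on its own, as a 2-methoxyphenyl group would show, or only alongside the other two methoxy groups. Also open, as far as these compounds go, is whether a different kind of group on this ring, such as an amine or a carboxylic acid, would move the number beyond the scatter, which none of the four compounds can say.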